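Swapping a benzylamino arm for pyrrolidine on a shared core

A few compounds are considered here, and "the series" means these few. Any claim that something is new, unique, unknown or untested is made for them only; others in the source may bear on it.

The compounds share one core and differ only in the group attached to it, and each is tested in a functional assay on MGC-803 cells (Homo sapiens) for inhibition, read by sulforhodamine B assay; a lower number here means a stronger inhibitor, a higher number a weaker inhibitor. Compound 1 `O=C1C(NC2CC2)=CC(=O)c2c1nc1n2[C@H]2OC[C@@H](O)[C@H]2OC1` gives only a limit, > 4000 nM, rather than a number. Compound 2 `O=C1C=C(NCc2ccccc2)C(=O)c2c1nc1n2[C@H]2OC[C@@H](O)[C@H]2OC1` gives 2670 nM. Compound 3 `COc1ccccc1NC1=CC(=O)c2c(nc3n2[C@H]2OC[C@@H](O)[C@H]2OC3)C1=O` gives 1670 nM. Among the measured compounds shown here, the one measured step with a clear direction, an at least 2.3-fold lower number from compound 1 to compound 3 (0.37 log units; beyond the scatter), shows that the choice of the amine substituent matters. Among the numbers shown, compound 2 and compound 3 lie within the usual scatter of each other, and the third value is a limit, so compound 2 cannot be placed above or below either neighbour with confidence.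

Compound 4 `O=C1C=C(N2CCCC2)C(=O)c2c1nc1n2[C@H]2OC[C@@H](O)[C@H]2OC1` is the next case: pyrrolidin-1-yl in place of benzylamino on a double-bonded ring carbon. For the measured compounds named here, no measured step replaces an amine bearing a hydrogen with a ring nitrogen, so the step of an at least 2.3-fold lower number from compound 1 to compound 3 (0.37 log units; beyond the scatter) bears on it only loosely, as a sign that smaller, non-aromatic groups have given the weaker result here. On that basis compound 4 is expected to be somewhat weaker than compound 2, with the estimated change being a 1.5-fold higher number from compound 2 to compound 4 (0.18 log units; within the scatter). The estimate for compound 4 in this assay is 4000 nM, within a range from 1500 nM to 12000 nM.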

Compound 4, half-maximal inhibitory concentration: > 16000 nM
Compound 4: only a limit was reported; the forecaster's own chance of this, stated with the estimate: 40%; middle value at least 4.0-fold (0.60 log units) from the limit.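

The exchange at this position, on a double-bonded ring carbon, costs clear activity in this assay, with an at least 5.9-fold higher number from compound 2 to compound 4 (0.77 log units; beyond the scatter), a step beyond the usual scatter, so replacing benzylamino with pyrrolidin-1-yl weakens inhibition rather than leaving it unchanged. The reading for compound 4 is a limit and not a number, so the true size of the loss stays unknown: the limit of > 16000 nM in this assay, at which 1 of the 4 values shown sits. This is also the only step shown in which the attached nitrogen loses its hydrogen, since the groups on compound 1 and compound 3 both keep a hydrogen-bond donor on that nitrogen, whereas pyrrolidin-1-yl has none.

The change from compound 2 to compound 4 removes the aromatic ring and the hydrogen-bond donor together and also shortens the group, so this single step cannot say which of these differences matters. Cyclopentylamino would keep the amine hydrogen while carrying a non-aromatic ring, and N-benzyl-N-methylamino would keep the aromatic ring without that hydrogen, so either group could help pull these differences apart.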